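Allyl in Place of Cyanoethyl on the Chain Nitrogen

A few compounds are considered here, and "the series" means these few. Any claim that something is new, unique, unknown or untested is made for them only; others in the source may bear on it.

Compound 1 `N#CCCNc1c(NC/C=C\COc2csc(CN3CCCCC3)c2)c(=O)c1=O` gives 0.31 ug/mL in a functional assay for antagonist activity at histamine H2 receptor (Cavia porcellus); a higher number here means a weaker inhibitor, a lower number a stronger inhibitor. Within the data shown here, of the two numbers recorded so far this is the lowest, but its only neighbour, compound 2 `COCC/N=c1\c(O)c(O)\c1=N/C/C=C\COc1csc(CN2CCCCC2)c1`, gives 0.48 ug/mL in this assay, and that gap lies within the scatter, so the two compounds cannot be ranked against each other. Compound 3 `C=CCNc1c(NC/C=C\COc2csc(CN3CCCCC3)c2)c(=O)c1=O` differs from compound 1 in one place: vinyl in place of cyanomethyl on a saturated chain carbon bound to a nitrogen on an aromatic ring. Among the measured compounds shown here, no pair of measured compounds shows this change in isolation, so there is nothing to read the size of the step from; the expectation rests on compound 1 alone. A small step is expected, with no clear direction, and most likely not beyond the scatter. Compound 3 is estimated at 0.45 ug/mL in this assay, with a range from 0.15 ug/mL to 1.3 ug/mL. That estimate means a step of a 1.5-fold higher number from compound 1 to compound 3 (0.16 log units; within the scatter), which is expected to stay inside the usual scatter.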

Compound 3, half-maximal inhibitory concentration: 0.51 ug/mL
Compound 3: the middle estimate sits 1.1-fold (0.05 log units) below what was measured; measured number inside the range.
By their numbers in this assay, from the lowest: compounds 1, 2 and 3 (each within the scatter of the next).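

Among these compounds, replacing cyanomethyl with vinyl on a saturated chain carbon bound to a nitrogen on an aromatic ring gives, in this assay, a 1.6-fold higher number from compound 1 to compound 3 (0.22 log units; within the scatter), the first direct reading of a change at this position. Compound 3 carries no nitrile, and the entering vinyl counts no hydrogen-bond acceptor, yet this pair cannot be told apart in this assay, so the nitrile is not needed at this position to stay within the scatter of compound 1. Nothing available explains this result in terms of how either group acts.

Still open, on these data alone, is whether the position accepts a group of another kind in place of allyl, such as a carboxylic acid, an amine or a longer chain. This single pair also leaves open whether the same change would read alike on a different core.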